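Bromine on the Fused Ring and Growth Inhibition

A few compounds are considered here, and "the series" means these few. Any claim that something is new, unique, unknown or untested is made for them only; others in the source may bear on it.

Compound 1, `COc1ccc(C2=NN(C3=NC(=O)/C(=C4\C(=O)Nc5ccccc54)S3)C(c3ccc(Cl)cc3)C2)cc1`, gives 100000 nM in a functional assay on cells (Cancer cell lines, Homo sapiens) for cytotoxicity, read by sulforhodamine B assay, with a stated time of 48 h; on this read-out higher numbers stand for weaker inhibition of growth and lower numbers for stronger inhibition of growth.
Compound 2, `COc1ccc(C2=NN(C3=NC(=O)/C(=C4\C(=O)Nc5ccc(Br)cc54)S3)C(c3ccc(Cl)cc3)C2)cc1`, gives 340 nM in this assay.
Compound 3, `CN(C)c1ccc(C2CC(c3ccccc3)=NN2C2=NC(=O)/C(=C3\C(=O)Nc4ccccc43)S2)cc1`, gives 25200 nM in this assay.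

Compound 2 differs from compound 1 by one change, (bromo in place of hydrogen on an aromatic carbon). Compound 3 carries a different core from compound 1; that difference is not broken down here. Compound 4, `CN(C)c1ccc(C2CC(c3ccccc3)=NN2C2=NC(=O)/C(=C3\C(=O)Nc4ccc(Br)cc43)S2)cc1`, is the not yet measured partner of compound 3 and differs from it by the same change, (bromo in place of hydrogen on an aromatic carbon), at the same place. For the measured compounds named here, the only measured instance of this change is the step of a 290-fold lower number from compound 1 to compound 2 (2.47 log units; beyond the scatter). A step of similar direction, though perhaps smaller on the core of compound 3, is expected, so the estimate for compound 4 is 300 nM, between 50 nM and 3000 nM, meaning an expected step of an 84-fold lower number from compound 3 to compound 4 (1.92 log units; beyond the scatter).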

Compound 4, concentration for total growth inhibition: 540 nM
Estimate against measurement, compound 4: 1.8-fold (0.26 log units) below, and the stated range covers the measured number.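

On the core of compound 3, bromo in place of hydrogen again lowers the number, giving a 47-fold lower number from compound 3 to compound 4 (1.67 log units; beyond the scatter) in this assay, so the direction of the change carries over between these two cores. For the compounds shown here, the size of the step does not carry over unchanged, and the gap between the two steps is larger than repeated measurements would be expected to produce: the same change on two cores in this assay, a 290-fold lower number (2.47 log units; beyond the scatter) from compound 1 to compound 2 and a 47-fold lower number (1.67 log units; beyond the scatter) from compound 3 to compound 4, 6.3-fold (0.80 log units) apart, beyond the scatter of two such steps Two cores are only two examples, and because they differ in more than one place, these results do not show which part of the core alters the size of the step.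

On these data alone, it remains open whether chloro, methoxy or an amine at the same place would lower the number as bromo does. As far as these compounds go, it is also open whether bromo would have a similar effect elsewhere on that ring.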